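The compounds below may be only part of what the source reports. "The series", "measured", "known", "first", "only" and "open" are said of these compounds alone.

The measured compounds:

Compound 1 `COc1ccc(-c2cc(=O)cco2)cc1`: in an ADME assay on HaCaT cells (Homo sapiens) for inhibition, read by sulforhodamine B assay, with a stated time of 48 h (on this read-out lower numbers stand for stronger inhibition of growth and higher numbers for weaker inhibition of growth), compound 1 gives > 1230 uM, which is a limit of the assay rather than a number.
Compound 2 `O=C1C=CCC(/C=C/c2ccccc2C(F)(F)F)O1`: in this assay compound 2 gives 82.7 uM.
Compound 3 `O=C1C=CCC(/C=C/c2ccc(C(F)(F)F)cc2)O1`: in this assay compound 3 gives 69.7 uM.

Compound 3 holds the lower of the two numbers shown, but its nearest neighbour, compound 2, sits within the scatter of it, so the two cannot be told apart. Among the compounds with values here, the only other value, that of compound 1, is a limit (the limit of > 1230 uM in this assay, at which 1 of the 3 values shown sits).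

Compound 4 `COc1ccc(/C=C/C2CC=CC(=O)O2)cc1` has not yet been measured. It differs from compound 3 in a single place: methoxy in place of trifluoromethyl on an aromatic carbon. Within the data shown here, no measured pair in this set differs by such a change alone, so the size of the step cannot be read off from the data. Among the measured compounds shown here, the one compound that does carry a methoxy group, compound 1, has a different core, and in this assay compound 1 gives only a limit. On that basis the step from compound 3 to compound 4 is expected to be modest and toward weaker inhibition, as a 2.3-fold higher number from compound 3 to compound 4 (0.36 log units; beyond the scatter) expresses. Compound 4 is therefore estimated at 160 uM, with a likely range from 50 uM to 600 uM.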

Compound 4, concentration for growth inhibition (reported as GI): 58.8 uM
Compound 4: the middle estimate sits 2.7-fold (0.43 log units) above what was measured; the measured number falls inside the stated range.
By their numbers in this assay, from the lowest: compounds 4, 3 and 2 (each within the scatter of the next). At a limit, above all of these: compound 1.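

In this assay, methoxy in place of trifluoromethyl on this aromatic carbon, para to a group of 9 heavy atoms, gives a 1.2-fold lower number from compound 3 to compound 4 (0.07 log units; within the scatter), so this first pair differing only at this place cannot be told apart. The two groups differ in their heavy atoms and in their hydrogen-bond acceptors, yet the read-out does not separate them at this position. No measurement shown bears on why the two groups read alike.

Going by these compounds, it remains open whether an amine or a carboxylic acid on this aromatic carbon would also read like compound 3 and compound 4. On these data alone, it is equally open whether a longer chain in place of the methoxy, or a methoxy on another carbon of the ring, would leave the number within the same scatter.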